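The source may report more compounds than this note shows. Statements on the series, on what has been measured and on what is new or still open speak of the compounds shown alone.

Compound 1 `CC1(Cc2ccccc2)C(=O)N(c2ccccc2)c2ncccc21` gives 9% in a functional assay on the whole organism (Pleural cavity) for inhibition, with Rattus norvegicus as the target, at a dose of 25 mg/kg; on this read-out higher numbers stand for more inhibition at the one dose given (going by the name of the read-out) and lower numbers for less inhibition.
Compound 2 `CC1(C)C(=O)N(Cc2ccccc2)c2ncccc21` gives 12% in this assay.

Both measured compounds share the same core and differ only in the groups attached to it. Compound 1 and compound 2 sit close together in this assay: the gap between their two numbers lies within the usual scatter of repeated measurements, so their inhibition in this assay is level, and both numbers are low at the dose tested. Within the data shown here, no step between two measured compounds that differ in a single place is available to guide a prediction. Compound 3 `CCCCC1(C)C(=O)N(c2ccccc2)c2ncccc21` differs from compound 1 in one place: propyl in place of phenyl on a saturated chain carbon bound to a saturated ring carbon. Among the measured compounds shown here, because compound 1 gives 9% and the only other measured compound lands within the scatter of that number, the step of a number 1 percentage points higher from compound 1 to compound 3 (within the scatter) is expected to be none beyond the scatter. Compound 3 is therefore estimated at 10%, with a range from 0% to 25%.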

Compound 3, a percentage reported as inhibition, in the whole organism at one dose (the size of the read-out at that dose, not a potency): 21%
The estimate for compound 3 lay 11 percentage points below the measured number; low and high end bracket the measured number.
By their numbers in this assay, from the lowest: compounds 1, 2 and 3 (each within the scatter of the next, the first and the last beyond it).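

Replacing phenyl with propyl on a saturated chain carbon bound to a saturated ring carbon gives a number 12 percentage points higher from compound 1 to compound 3 (beyond the scatter) in this assay. Among these compounds, this is the first single change that can be read on its own, and it shows that this position responds to the group placed there, and that an open chain with no ring can give more inhibition here than the aromatic ring it replaces. No measurement at hand explains the step, so it records only what happened and not why.

From the compounds shown here alone, whether a longer chain, such as pentyl or hexyl, would raise the inhibition further remains open, as does the effect of ending the chain in an amine or a carboxylic acid. Even compound 3 reaches only 21%, so much of the scale remains unfilled at this dose.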